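A few compounds are considered here, and "the series" means these few. Any claim that something is new, unique, unknown or untested is made for them only; others in the source may bear on it.

Compound 1 `CC(C)(C)Sc1c(CC(C)(C)C(=O)O)n(Cc2ccc(Cl)cc2)c2ccc(OCc3ccc4cccnc4n3)cc12` was tested in a functional assay (blood) for inhibition, with Homo sapiens as the target; a higher number here means a weaker inhibitor, a lower number a stronger inhibitor. Compound 1 gives only a limit there, > 3000 nM, not a number. Compound 2 `CC(C)(C)Sc1c(CC(C)(C)C(=O)O)n(Cc2ccc(Cl)cc2)c2ccc(OCc3cccnc3)cc12` likewise gives only a limit, > 3000 nM. Compound 3 `C[C@H](COc1ccc2c(c1)c(SC(C)(C)C)c(CC(C)(C)C(=O)O)n2Cc1ccc(Cl)cc1)c1ccccn1` gives 470 nM in this assay. Two of the three values sit at the limit of > 3000 nM in this assay, at which 2 of the 3 values shown sit, so compound 1 stands at the weak end; the step that the two limits leave unreadable from compound 1 to compound 2 is unreadable, whereas an at least 6.3-fold lower number from compound 1 to compound 3 (0.80 log units; beyond the scatter) and an at least 6.3-fold lower number from compound 2 to compound 3 (0.80 log units; beyond the scatter) both lie beyond the scatter. Compound 4 `CC(C)c1csc(COc2ccc3c(c2)c(SC(C)(C)C)c(CC(C)(C)C(=O)O)n3Cc2ccc(Cl)cc2)n1` differs from compound 1 by a group of 8 heavy atoms (6 carbon, 1 nitrogen, 1 sulfur; one five-membered aromatic ring with 2 hetero atoms) in place of a group of 10 heavy atoms (8 carbon, 2 nitrogen; 2 six-membered aromatic rings with 1 hetero atom each), on a saturated chain carbon bound to an oxygen on an aromatic ring. For the measured compounds named here, this swap is of the same kind as the one from compound 1 to compound 3, though with a different entering group, so a drop is expected with limited confidence. Compound 4 is estimated at 1200 nM, between 300 nM and 5000 nM, an expected at least 2.5-fold lower number from compound 1 to compound 4 (0.39 log units; beyond the scatter).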

Compound 4, half-maximal inhibitory concentration: > 3000 nM
Compound 4 gave a limit, no number (the forecaster's own chance of this, stated with the estimate: 35%); middle value at least 2.5-fold (0.39 log units) away from the limit.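

On the saturated chain carbon bound to an oxygen on an aromatic ring, 4-isopropyl-1,3-thiazol-2-yl does not match 1-(pyridin-2-yl)ethyl in this assay: an at least 6.3-fold higher number from compound 3 to compound 4 (0.80 log units; beyond the scatter). The groups entering in compound 3 and compound 4 hold the same count of heavy atoms, so that count alone does not separate these two compounds. The steps linking compound 4 with compound 1 and compound 2 cannot be read, because all three sit at a limit: the limit of > 3000 nM in this assay, at which 3 of the 4 values shown sit.

Going by these compounds, how far apart compound 1, compound 2 and compound 4 truly lie stays open. Also open, on these data alone, is whether a simple amine or an unsubstituted thiazol-2-yl in this place would come closer to compound 3.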